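The compounds below may be only part of what the source reports. "The series", "measured", "known", "first", "only" and "open" are said of these compounds alone.

Compound 1 (`COc1ccc(Nc2ncc(C(F)(F)F)c(N3Cc4cccc(N(C)S(C)(=O)=O)c4C3)n2)cc1C(F)(F)F`): 29400 nM
Compound 2 (`CN(c1cccc2c1CN(c1nc(Nc3cccc(Oc4ccccc4)c3)ncc1C(F)(F)F)C2)S(C)(=O)=O`): 19500 nM

In a functional assay on U-87MG ATCC cells for antiproliferative activity against U-87 MG (Homo sapiens), read by spectrophotometry, with a stated time of 2 days (a lower number here means a stronger inhibitor of growth, a higher number a weaker inhibitor of growth), compound 1 gives 29400 nM and compound 2 gives 19500 nM as its value. Among the compounds with values here, these two numbers lie within the usual scatter of each other, so they set no order between the compounds, and compound 1 stands level with compound 2.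

Compound 3 (`COc1cc(Nc2ncc(C(F)(F)F)c(N3Cc4cccc(N(C)S(C)(=O)=O)c4C3)n2)cc(OC)c1`) has not yet been measured. It keeps the core of compound 1 and carries 3,5-dimethoxyphenyl in place of 4-methoxy-3-(trifluoromethyl)phenyl on a nitrogen on an aromatic ring.

Within the data shown here, no step between measured compounds that differ in one place is available, so the data do not show directly what such a change does in this assay on this core. Among the measured compounds shown here, the only guide is that compound 2 at 19500 nM stays within the scatter of compound 1 at 29400 nM in this series. No step beyond the scatter is therefore expected, in either direction.

The expected change is small (a 1.3-fold lower number from compound 1 to compound 3 (0.13 log units; within the scatter)). The estimated value for compound 3 is 22000 nM with 8000 nM to 50000 nM as the expected range.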

Compound 3, concentration for 50% growth inhibition: > 30000 nM
Compound 3: no number, only a limit; the forecaster's own chance of this, stated with the estimate: 15%; middle value at least 1.3-fold (0.13 log units) away from the limit.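

Compound 3 gives > 30000 nM in this assay, and this is a limit of the assay, not a number. Placing 3,5-dimethoxyphenyl in place of 4-methoxy-3-(trifluoromethyl)phenyl on a nitrogen on an aromatic ring gives an at least 1.0-fold higher number from compound 1 to compound 3 (0.00 log units; that floor lies within the scatter), so this change to the core of compound 1 shows no lowering of the number, and the step is only a floor whose true size cannot be read. The result therefore adds a one-place comparison that the earlier compounds did not offer, but it marks the edge of what the assay can report rather than a measured effect of the change: the limit of > 30000 nM in this assay, at which 1 of the 3 values shown sits.

The compounds shown leave open how far beyond the limit compound 3 lies, and so whether the step from compound 1 is within the scatter or well beyond it. They also leave open whether an amine or a carboxylic acid on the phenyl ring, in place of the methoxy or trifluoromethyl groups, would bring the number beyond the scatter of compound 1 on this core.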